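This account rests on a few compounds, and the source may have more. Where it says the series, first, only, none or still open, it means among the compounds named here.

Measured in a functional assay on HL-60 cells (Homo sapiens) for inhibition, with a stated time of 24 h; on this read-out lower numbers stand for stronger inhibition and higher numbers for weaker inhibition:
- compound 1 `O=c1[nH]c(=O)n([C@H]2C[C@H](O)[C@@H](CO)O2)cc1CF`: 178 uM
- compound 2 `CC(=O)OC[C@H]1O[C@@H](n2cc(C(F)F)c(=O)[nH]c2=O)C[C@@H]1OC(C)=O`: 83 uM

Of these two numbers, compound 1 holds the higher one, so it is the weaker inhibitor in this assay. The gap to compound 2 lies beyond the scatter.

The next compound to be read is compound 3 `O=c1[nH]c(=O)n([C@H]2C[C@H](O)[C@@H](CO)O2)cc1C(F)F`. It differs from compound 1 by fluoro in place of hydrogen on a saturated chain carbon bound to an aromatic carbon and a fluorine atom. This is fluoro in place of hydrogen on a saturated chain carbon bound to an aromatic carbon and a fluorine atom, or, cut one bond further out, fluoromethyl to difluoromethyl.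

For the measured compounds named here, no measured pair isolates this change, so the expectation rests on thin evidence. Going by the values given here, the only other number available is that of compound 2, at 83 uM, and it gives no direct reading of the step. A modest move toward a lower number is expected, and it may not exceed the scatter. The expected size is a 1.6-fold lower number from compound 1 to compound 3 (0.21 log units; within the scatter).

For compound 3 the estimated value is 110 uM, with an expected range of 40 uM to 260 uM.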

Compound 3, concentration for 50% inhibition: 4 uM
The estimate for compound 3 lay 28-fold (1.44 log units) above the measured number; measured number outside the range, below it.
By their numbers in this assay, from the lowest: compound 3; then compound 2; then compound 1.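

In this assay, a single fluoro in place of hydrogen on a saturated chain carbon bound to an aromatic carbon and a fluorine atom gives a 45-fold lower number from compound 1 to compound 3 (1.65 log units; beyond the scatter). This position therefore responds steeply to the change from fluoromethyl to difluoromethyl, which the two earlier numbers could not show, as compound 1 and compound 2 differ in more than one place. For the compounds shown here, the step is so far the only one between compounds differing in one place, so it stands as a single observation and not as a trend, and nothing available bears on its origin.

Still open, going by these compounds, is whether trifluoromethyl on the same carbon would carry the direction of this step further or reverse it, and how a chloromethyl group or a longer chain such as ethyl would read in this assay. Also open, on these data alone, is whether the size of the step from fluoromethyl to difluoromethyl holds on the core of compound 1 in any other cell line or at any other exposure time.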